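From tert-Butyl to Ethyl on a Cyanoaziridine Urea

A few compounds are considered here, and "the series" means these few. Any claim that something is new, unique, unknown or untested is made for them only; others in the source may bear on it.

compound 1, `N#CC1CN1C(=O)Nc1ccc(F)cc1`: 2400 nM
compound 2, `CC(C)(C)NC(=O)N1CC1C#N`: 190000 nM
compound 3, `N#CC1CN1C(=O)Nc1cccc2ccccc12`: 1700 nM

In a functional assay on MCF7 cells (Homo sapiens) for inhibition (a lower number here means a stronger inhibitor, a higher number a weaker inhibitor), compound 2 gives the highest number of the three, at 190000 nM. Compound 1 gives 2400 nM and compound 3 gives 1700 nM; both gaps to compound 2 lie far beyond the scatter. Going by the values given here, compound 2 is the only one of the three whose urea nitrogen carries a saturated alkyl group rather than an aromatic one, and no measured pair isolates any single change on that nitrogen.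

Compound 4, `CCNC(=O)N1CC1C#N`, remains to be measured in this assay. It differs from compound 2 by ethyl in place of tert-butyl on an amide-type nitrogen. Among the compounds with values here, the three measured compounds offer no step of this kind, so the direction of the change is open; the only guidance is that both measured alkyl-free compounds sit far below compound 2, while compound 4 keeps an alkyl group on the urea nitrogen. The step of a 1.3-fold lower number from compound 2 to compound 4 (0.10 log units; within the scatter) is therefore expected to be modest and, in either direction, not clearly beyond the scatter. Compound 4 is estimated at 150000 nM, within a range from 30000 nM to 600000 nM.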

Compound 4, half-maximal inhibitory concentration: 20000 nM
For compound 4 the middle estimate is 7.5-fold (0.88 log units) above the measured one; the whole stated range lies above it.
By their numbers in this assay, from the lowest: compounds 3 and 1 (each within the scatter of the next); then compound 4; then compound 2.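

Going by these compounds alone, replacing tert-butyl with ethyl on the amide-type nitrogen gives a 9.5-fold lower number from compound 2 to compound 4 (0.98 log units; beyond the scatter) in this assay, the first measured change confined to this position. The very high number of compound 2 therefore does not hold for alkyl groups on this nitrogen in general: the identity of the alkyl group itself matters, even with no aromatic group present. Even so, compound 4 at 20000 nM still gives a higher number than compound 1 at 2400 nM and compound 3 at 1700 nM, and nothing available explains why the ethyl compound gives the lower number of the two alkyl compounds.

The compounds shown leave open whether the number depends on the branching of tert-butyl or on the size of the group, since this one step changes both at once. Isopropyl, which is branched, and a straight propyl or butyl chain would help separate the two, while methyl or the unsubstituted amide hydrogen on this nitrogen would show whether the number keeps falling as the alkyl group is cut back further.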